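Boc removal on the aryl amine of compound 3

This account rests on a few compounds, and the source may have more. Where it says the series, first, only, none or still open, it means among the compounds named here.

Series notes. In a functional assay on MCF7 cells (Homo sapiens) for antiproliferative activity, read by MTT assay, with a stated time of 72 h (a lower number here means a stronger inhibitor, a higher number a weaker inhibitor), compound 1 `O=C(Nc1ccccc1C(=O)O/N=C1\CCCc2noc(-c3ccc(F)cc3)c21)c1ccccc1F` returns only a limit, > 25000 nM. Compound 2 `O=C(Nc1cccc(C(=O)O/N=C2\CCCc3onc(-c4cccc(F)c4)c32)c1)c1cccc(F)c1` gives a number in this assay, 4700 nM. Compound 3 `CC(C)(C)OC(=O)Nc1cccc(C(=O)Nc2cccc(C(=O)O/N=C3\CCCc4onc(-c5ccc(F)cc5)c43)c2)c1` again returns only a limit in this assay, > 25000 nM. For the measured compounds named here, since two of the three values sit at that limit (the limit of > 25000 nM in this assay, at which 2 of the 3 values shown sit), no step between measured compounds can be drawn, and compound 3 stands simply as one of the two compounds with no number, at the weaker side of what was measured. Compound 4 `Nc1cccc(C(=O)Nc2cccc(C(=O)O/N=C3\CCCc4onc(-c5ccc(F)cc5)c43)c2)c1` differs from compound 3 by hydrogen in place of tert-butoxycarbonyl on a nitrogen on an aromatic ring. Going by the values given here, no measured pair tells how this change reads here; a move toward stronger inhibition is expected, but small and uncertain, with a fair chance of another limit. Compound 4 is therefore estimated at 15000 nM, between 4000 nM and 25000 nM, the expected step being an at least 1.6-fold lower number from compound 3 to compound 4 (0.22 log units; that floor lies within the scatter).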

Compound 4, half-maximal inhibitory concentration: > 25000 nM
Compound 4 gave a limit, no number; the forecaster's own chance of this, stated with the estimate: 50%; middle value at least 1.6-fold (0.22 log units) from the limit.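

Compound 3 and compound 4 both give only a limit in this assay, so no step can be read between them: the limit of > 25000 nM in this assay, at which 3 of the 4 values shown sit.

The compounds shown leave open how the change from (tert-butoxycarbonyl)amino to amino reads where both partners give a number.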